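The source may hold more compounds than are shown below. What is called first, only, known or untested is meant among the compounds shown, and "the series" means these compounds.

Measured compounds in a functional assay on WM 266-4 cells (Homo sapiens) for antiproliferative activity, read by MTT assay, with a stated time of 48 h; a higher number here means a weaker inhibitor of growth, a lower number a stronger inhibitor of growth:
compound 1, `S=C(Nc1ccccc1)N1N=C(c2ccccc2)CC1c1ccc2c(c1)OCCO2`, gives 3180 nM.
compound 2, `S=C(Nc1ccccc1)N1N=C(c2ccc(Cl)cc2)CC1c1ccc2c(c1)OCCO2`, gives only a limit of the assay, > 200000 nM.
compound 3, `COc1cccc(C2=NN(C(=S)Nc3ccccc3)C(c3ccc4c(c3)OCCO4)C2)c1`, gives 1380 nM.

Compound 2 therefore stands apart from the other two: its result is the limit of > 200000 nM in this assay, at which 1 of the 3 values shown sits, so no number is known for it, only a limit. Compound 4, `Cc1ccc(C2=NN(C(=S)Nc3ccccc3)C(c3ccc4c(c3)OCCO4)C2)cc1C`, is the compound still to be measured. It differs from compound 2 in one place: 3,4-dimethylphenyl in place of 4-chlorophenyl on a carbon with a double bond to nitrogen.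

Within the data shown here, two measured steps bear directly on this change. The first is an at least 62-fold higher number from compound 1 to compound 2 (1.79 log units; beyond the scatter), which shows that the 4-chlorophenyl group alone carries the loss seen in compound 2. The second is an at least 140-fold lower number from compound 2 to compound 3 (2.16 log units; beyond the scatter), which shows that exchanging the 4-chlorophenyl group for a differently substituted phenyl restores measurable growth inhibition. A third step, a 2.3-fold lower number from compound 1 to compound 3 (0.36 log units; beyond the scatter), shows that a substituent on this phenyl ring can also bring a modest gain over compound 1. Taken together, a large step downward in this assay is expected on going to compound 4, of about an at least 66-fold lower number from compound 2 to compound 4 (1.82 log units; beyond the scatter). Compound 4 is thus estimated at 3000 nM, with a range from 700 nM to 30000 nM.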

Compound 4, concentration for 50% growth inhibition: 70500 nM
Beside the measured number, compound 4's estimate is 24-fold (1.37 log units) below it, outside the stated range (above it).
By their numbers in this assay, from the lowest: compound 3; then compound 1; then compound 4. At a limit, above all of these: compound 2.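

In this assay, among these compounds, the aryl group on the carbon with a double bond to nitrogen proves more demanding than the earlier compounds could show: moving away from 4-chlorophenyl does not by itself restore growth inhibition to the level of compound 1 or compound 3, since 3,4-dimethylphenyl gives an at least 2.8-fold lower number from compound 2 to compound 4 (0.45 log units; beyond the scatter). The same group gives a 51-fold higher number from compound 3 to compound 4 (1.71 log units; beyond the scatter) and a 22-fold higher number from compound 1 to compound 4 (1.35 log units; beyond the scatter), so a substituted phenyl here can lie far from the plain phenyl in either direction, with the 3-methoxyphenyl of compound 3 on the stronger side and the 3,4-dimethylphenyl of compound 4 on the weaker side. The result for compound 2 is a limit and not a number, so the first of these steps gives only a bound: the limit of > 200000 nM in this assay, at which 1 of the 4 values shown sits.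

The compounds shown leave open how a single methyl group on this phenyl ring would compare with the two methyl groups of compound 4. They also leave open whether an amine or a carboxylic acid on this ring would stand nearer to compound 3 or to compound 4.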